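Swapping a Branched Alkenyl Chain for a Plain Allyl Group

The source may hold more compounds than are shown below. What is called first, only, known or untested is meant among the compounds shown, and "the series" means these compounds.

Compound 1, `C=CC(C)(C)c1cc(-c2ccc(OC)cc2)ccc1O`: > 100000 nM
Compound 2, `C=CCc1cc(C=O)c(OCC)c(-c2ccc(OCC)c(CC=C)c2)c1`: 31900 nM
Compound 3, `C=CCc1cc(-c2cccc(C(F)(F)F)c2)ccc1O`: 65900 nM

In a functional assay on Lewis lung carcinoma cells (Mus musculus) for antiproliferative activity, read by MTT assay, with a stated time of 24 h (on this read-out lower numbers stand for stronger inhibition and higher numbers for weaker inhibition), compound 1 is recorded only as a limit, > 100000 nM, which is the edge of what the test can report rather than a measured number. That limit is the one described in the limit of > 100000 nM in this assay, at which 1 of the 3 values shown sits. Compound 2 gives 31900 nM in this assay, and compound 3 gives 65900 nM. Going by the values given here, both are weak, and neither differs from compound 1 in a single place, so no measured step leads away from compound 1.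

Compound 4, `C=CCc1cc(-c2ccc(OC)cc2)ccc1O`, is the next compound to be tested. It differs from compound 1 by allyl in place of 1,1-dimethylprop-2-en-1-yl on an aromatic carbon. The hydroxy group and the group of 8 heavy atoms stay where they are; only the chain on the aromatic carbon is exchanged.

Because compound 2 gives 31900 nM and compound 3 gives 65900 nM, compound 4 is expected to remain a weak inhibitor in this assay. Compound 4 is expected to give about 70000 nM, with a range from 25000 nM to 200000 nM. The expected step of an at least 1.4-fold lower number from compound 1 to compound 4 (0.15 log units; that floor lies within the scatter) is toward somewhat stronger inhibition, but it is read against a limit and may well fall within the usual scatter.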

Compound 4, half-maximal inhibitory concentration: > 100000 nM
Compound 4 ended at the assay's limit (the forecaster's own chance of this, stated with the estimate: 40%); middle value at least 1.4-fold (0.15 log units) away from the limit.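

Compound 1 and compound 4 both stop at a limit of the test rather than at a measured number, so no step can be read between them: the limit of > 100000 nM in this assay, at which 2 of the 4 values shown sit. The compounds shown leave open whether exchanging the 1,1-dimethylprop-2-en-1-yl chain for allyl changes inhibition in this assay at all, and in which direction.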